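Dimethylamino on the benzoyl ring of a hydroxamic acid

The source may hold more compounds than are shown below. What is called first, only, known or untested is meant among the compounds shown, and "the series" means these compounds.

Compound 1 `O=C(CCN(Cc1ccc(C(=O)NO)cc1)C(=O)c1ccccc1)NCc1ccccc1` and compound 2 `Cc1ccc(NC(=O)CCN(Cc2ccc(C(=O)NO)cc2)C(=O)c2ccccc2)cc1` share a hydroxamic acid core and were both tested in a functional assay on CHP-134 cells (Homo sapiens) for antiproliferative activity, with a stated time of 72 h; a higher number here means a weaker inhibitor, a lower number a stronger inhibitor. In that assay compound 1 gives 4680 nM, and compound 2 gives 1160 nM. Compound 1 therefore stands as the higher of the two numbers, separated from compound 2 by a 4.0-fold lower number from compound 1 to compound 2 (0.61 log units; beyond the scatter), which comes from 4-methylphenyl in place of benzyl on an amide-type nitrogen. Compound 3 `CN(C)c1ccc(C(=O)N(CCC(=O)NCc2ccccc2)Cc2ccc(C(=O)NO)cc2)cc1` differs from compound 1 at another place: dimethylamino in place of hydrogen on an aromatic carbon. No measured step touches this position; the one step shown alters a different part of the shared core and offers no guide to size or direction here. With nothing to anchor a shift, the expected step is a 1.2-fold lower number from compound 1 to compound 3 (0.07 log units; within the scatter), not beyond the scatter. Compound 3 is accordingly estimated at 4000 nM, with a range from 1500 nM to 11000 nM.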

Compound 3, half-maximal inhibitory concentration: 1160 nM
Compound 3: the middle estimate sits 3.4-fold (0.54 log units) above what was measured; the measured number lies below the stated range.
By their numbers in this assay, from the lowest: compounds 2 and 3 (each within the scatter of the next); then compound 1.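

In this assay, the change from phenyl to 4-(dimethylamino)phenyl gives a 4.0-fold lower number from compound 1 to compound 3 (0.61 log units; beyond the scatter), so this aromatic carbon, para to a large group, responds to substitution. The earlier step had shown this only for the group on the amide-type nitrogen, and the shared core now has a second place where a single change moves the number beyond the scatter. Nothing available explains why the number moves at this position.

As far as these compounds go, it remains open whether this shift is specific to dimethylamino or would also follow from a primary amine, a methoxy group or a carboxylic acid on the same carbon. Also open, from the compounds shown here alone, is whether dimethylamino and 4-methylphenyl would add up when carried together on one compound.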